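The source may report more compounds than this note shows. Statements on the series, on what has been measured and on what is new or still open speak of the compounds shown alone.

Measured in an ADME assay on microsomes from liver (Mus musculus) for metabolic stability; a lower number here means that the compound disappears faster, a higher number that the compound lasts longer:
- compound 1 `CCc1cnc(OCC(C)(C)O)c(-c2ccc(S(C)(=O)=O)cc2)c1`: 0.22 h
- compound 2 `CCCOc1nc(OCC(C)(C)O)c(-c2ccc(S(C)(=O)=O)cc2)cc1CO`: 0.327 h

In this assay, compound 2 stands within the scatter of compound 1, so these two numbers set no order. Among the measured compounds shown here, their structures differ in more than one place, and no measured pair isolates a single change.

The next compound, compound 3 `CCCCOc1nc(OCC(C)(C)O)c(-c2ccc(S(C)(=O)=O)cc2)cc1CO`, differs from compound 2 by methyl in place of hydrogen on a saturated chain carbon, three bonds along the chain from an oxygen on an aromatic ring. Cut one bond further out, the same difference reads propyl to butyl. The series holds no measurement of this change, so the expectation has no direct support. A small move towards a shorter half-life is expected, but none beyond the scatter, starting from compound 2 at 0.327 h. The estimated step is a 1.2-fold lower number from compound 2 to compound 3 (0.08 log units; within the scatter). In this assay, compound 3 is expected at 0.27 h, with an estimated range of 0.14 h to 0.5 h.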

Compound 3, half-life: 0.045 h
Compound 3: middle estimate off by 6.0-fold (0.78 log units), on the high side; measured number below the stated range.
By their numbers in this assay, from the lowest: compound 3; then compounds 1 and 2 (each within the scatter of the next).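

In this assay the propyl to butyl change, on a saturated chain carbon three bonds along the chain from an oxygen on an aromatic ring, gives a 7.3-fold lower number from compound 2 to compound 3 (0.86 log units; beyond the scatter) and so marks this position as sensitive to chain length. Among the compounds shown here, a single added methyl is enough here to carry the number beyond the scatter, which no earlier pair could show, as none isolated one change. No measurement on these compounds accounts for the size of this step.

From the compounds shown here alone, this rests on one pair, so it stays open whether methyl to ethyl or ethyl to propyl at this place would give a step of similar size. Also open, going by these compounds, is whether a pentyl chain or a cyclopropylmethyl group would extend this drop or reverse it.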